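Amino at the Core: Two Scaffolds, One Kind of Change

The source may report more compounds than this note shows. Statements on the series, on what has been measured and on what is new or still open speak of the compounds shown alone.

Three compounds have been measured in a functional assay on HCT-116 cells (Homo sapiens), read by MTT assay, with a stated time of 72 h; on this read-out higher numbers stand for weaker inhibition and lower numbers for stronger inhibition:

Compound 1, `COc1ncnc2c1c(-c1cccs1)cn2[C@@H]1O[C@H](CO)[C@@H](O)[C@H]1O`: compound 1 gives 440 nM.
Compound 2, `COc1nc(N)nc2c1c(-c1cccs1)cn2[C@@H]1O[C@H](CO)[C@@H](O)[C@H]1O`: compound 2 gives > 20000 nM, which is a limit of the assay and not a number.
Compound 3, `O=c1[nH]cnc2c1c(-c1ccco1)cn2[C@@H]1O[C@H](CO)[C@@H](O)[C@H]1O`: compound 3 gives > 20000 nM, likewise a limit of the assay.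

Compound 1 and compound 2 share a core and differ in one place, (amino in place of hydrogen on an aromatic carbon). In this assay the step is an at least 45-fold higher number from compound 1 to compound 2 (1.65 log units; beyond the scatter). Compound 3 rests on another core; the difference between the two cores is not broken down here. Compound 4, `Nc1nc2c(c(-c3ccco3)cn2[C@@H]2O[C@H](CO)[C@@H](O)[C@H]2O)c(=O)[nH]1`, has not yet been measured and is related to compound 3 by amino in place of hydrogen on an aromatic carbon. The two changes are the same kind of change, not the same: in compound 2 the entering amino stands meta to a methoxy group (2 heavy atoms), in compound 4 meta to a group of 1 heavy atom.

For compound 4 a step that the limit leaves unreadable from compound 3 to compound 4 is expected in this assay, because an at least 45-fold higher number from compound 1 to compound 2 (1.65 log units; beyond the scatter) shows the same kind of change leaving no lower number and because the limit of > 20000 nM in this assay, at which 2 of the 3 values shown sit, already holds compound 3. Compound 4 is therefore expected to give 40000 nM, most probably reported again only as a limit. The expected range for compound 4 runs from 15000 nM to 200000 nM.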

Compound 4, half-maximal inhibitory concentration: > 20000 nM
Compound 4 was reported as a limit; the forecaster's own chance of this, stated with the estimate: 90%; the middle value is on the limit's open side.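

In this assay compound 4 gives > 20000 nM, which is a limit of the assay and not a number. Going by these compounds alone, compound 3 also stands only as a limit, and no step from compound 3 to compound 4 can be read. The compounds shown leave open whether amino in place of hydrogen on an aromatic carbon changes the number at all on the core of compound 3, because both values are held by the same limit: the limit of > 20000 nM in this assay, at which 3 of the 4 values shown sit.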